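A few compounds are considered here, and "the series" means these few. Any claim that something is new, unique, unknown or untested is made for them only; others in the source may bear on it.

In a functional assay on B16-F10 cells (Mus musculus) for cytotoxicity (a higher number here means a weaker inhibitor, a lower number a stronger inhibitor), compound 1 `O=c1oc2ccccc2c2nc3c(ccc4cc[nH]c43)c(-c3ccc(Br)cc3)c12` gives 70700 nM. Compound 2 `O=c1oc2ccccc2c2nc3c(ccc4cc[nH]c43)c(-c3c(Cl)cccc3Cl)c12` gives 70700 nM, and compound 3 `O=c1oc2ccccc2c2nc3c(ccc4cc[nH]c43)c(-c3ccccc3)c12` gives 70700 nM, so compound 1 stands level with both of them at the digits shown. The step of no change at the digits printed from compound 1 to compound 2 (within the scatter) and the step of no change at the digits printed from compound 1 to compound 3 (within the scatter) each stay inside the scatter, and so does no change at the digits printed from compound 2 to compound 3 (within the scatter): exchanging the group on that aromatic carbon for 2,6-dichlorophenyl, for phenyl, or for 4-bromophenyl leaves the measured concentration where it was.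

Compound 4 `O=c1oc2ccccc2c2nc3c(ccc4cc[nH]c43)c(-c3ccc(Cl)cc3)c12` differs from compound 1 in one place: chloro in place of bromo on an aromatic carbon. The closest measured guide is the exchange of bromo for hydrogen from compound 1 to compound 3, which gave no change at the digits shown; the other two steps, which alter the same group more heavily, likewise stayed within the scatter. Since none of the measured steps among these three compounds moves the read-out, exchanging bromo for chloro is expected to move it no further than the scatter, in no particular direction.

Compound 4 is therefore estimated at 70700 nM, within 35000 nM to 141000 nM. The step of no change at the digits printed from compound 1 to compound 4 (within the scatter) is expected to be nothing beyond the scatter.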

Compound 4, half-maximal inhibitory concentration: 70700 nM
Beside the measured number, compound 4's estimate shows no gap at the digits printed; measured number inside the range.
By their numbers in this assay, from the lowest: compounds 1, 2, 3 and 4 (each within the scatter of the next).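

In this assay, exchanging bromo for chloro on an aromatic carbon para to a large group gives no change at the digits printed from compound 1 to compound 4 (within the scatter) and so replaces one halogen with another at this position without shifting the read-out. Placing chloro where compound 3 carries hydrogen gives no change at the digits printed from compound 3 to compound 4 (within the scatter) and going from the 2,6-dichlorophenyl group to the 4-chlorophenyl group gives no change at the digits printed from compound 2 to compound 4 (within the scatter), so the single chloro reads the same as bromo, as hydrogen and as the two chloro groups of compound 2. Nothing available accounts for these four compounds reading alike.

All the groups shown here are a plain phenyl ring or that ring carrying halogens, so it remains open whether an amine, a carboxylic acid or a longer chain at this position would move the number at all. On these data alone, it also remains open whether a change elsewhere on the shared core, such as replacing the ring hydrogen on nitrogen with a methyl group, would shift the result in this assay when the chloro or bromo stays in place.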